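Amide nitrogen substituent swap on a sulfonamide core

This account rests on a few compounds, and the source may have more. Where it says the series, first, only, none or still open, it means among the compounds named here.

Measured compounds:
compound 1 `COc1ccc(Cl)cc1S(=O)(=O)Nc1cncc(C(=O)Nc2ccccc2)c1`: 310 nM
compound 2 `COc1ccc(OC(F)(F)F)cc1S(=O)(=O)Nc1cncc(C(N)=O)c1`: 131 nM

In an assay on isolated protein for inhibition of alkaline phosphatase, tissue-nonspecific isozyme (Homo sapiens) (on this read-out lower numbers stand for stronger inhibition and higher numbers for weaker inhibition), compound 1 gives 310 nM and holds the highest number of the two measured. Within the data shown here, compound 2 gives 131 nM, a lower number that lies beyond the usual scatter; the two compounds differ in more than one place, so no single step between them is known. Compound 3 `CCNC(=O)c1cncc(NS(=O)(=O)c2cc(Cl)ccc2OC)c1` follows from compound 1 by one change: ethyl in place of phenyl on an amide-type nitrogen. Among the measured compounds shown here, no measured pair in this set shows the effect of such a change on its own. Compound 2 carries a primary amide and gives the lower number, but its other differences prevent any firm reading. The step from compound 1 to compound 3 is therefore expected to be small, a 1.2-fold lower number from compound 1 to compound 3 (0.09 log units; within the scatter), with no clear direction beyond the scatter. Compound 3 is estimated at 250 nM, within a range from 80 nM to 800 nM.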

Compound 3, half-maximal inhibitory concentration: 193 nM
Compound 3: middle estimate off by 1.3-fold (0.11 log units), on the high side; the range from low to high includes it.
By their numbers in this assay, from the lowest: compounds 2, 3 and 1 (each within the scatter of the next, the first and the last beyond it).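

In this assay, the first step read at this amide-type nitrogen is a 1.6-fold lower number from compound 1 to compound 3 (0.21 log units; within the scatter) for ethyl in place of phenyl. On the core of compound 1, then, this position accepts the loss of the aromatic ring, with ethyl's 2 heavy atoms replacing phenyl's 6, and the read-out shows no change beyond the scatter. No measurement shown here offers an explanation for this result.

As far as these compounds go, what a hydrogen in place of ethyl would give on this core remains open: compound 2 carries a primary amide, but it also differs elsewhere, so it cannot settle the question. Also open, from the compounds shown here alone, are a longer chain, a cyclopropyl ring or a chain ending in an amine on this nitrogen, and whether the same step would read alike with trifluoromethoxy in place of chlorine.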